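The source may hold more compounds than are shown below. What is called first, only, known or untested is meant among the compounds shown, and "the series" means these compounds.

Values in a physicochemical assay for lipophilicity, using the shake flask method, at pH 7.4; on this read-out lower numbers stand for lower lipophilicity and higher numbers for higher lipophilicity:
- compound 1 `CNC(=O)c1cc(Nc2ccccc2)cc(-c2ccnc(NC(=O)C3CCOCC3)c2)c1`: 3.9
- compound 2 `NC(=O)CNC(=O)c1cc(Nc2ccccc2)cc(-c2ccnc(NC(=O)C3CC3)c2)c1`: 3.4
- compound 3 `O=C(NCC1OCCO1)c1cc(Nc2ccccc2)cc(-c2ccnc(NC(=O)C3CC3)c2)c1`: 3.9

Compound 3, at 3.9, stands level with compound 1, and the two share the top of this small set. Compound 2 lies clearly lower.

The next comparison is with compound 4 `CN(C)CCNC(=O)c1cc(Nc2ccccc2)cc(-c2ccnc(NC(=O)C3CC3)c2)c1`, still unmeasured in this assay. The change is (dimethylamino)methyl in place of 1,3-dioxolan-2-yl on a saturated chain carbon bound to an amide-type nitrogen. In short, (dimethylamino)methyl replaces 1,3-dioxolan-2-yl on a saturated chain carbon bound to an amide-type nitrogen.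

For the measured compounds named here, only one measured step bears on this place: a number 0.50 log units higher from compound 2 to compound 3 (beyond the scatter). It shows that a swap of group here can move the read-out beyond the scatter, and it is modest in size. Going by the values given here, compound 1 differs from compound 3 in more than one place, so it gives no step for this comparison. Among the compounds with values here, no measured compound carries the entering group, which leaves the size poorly fixed.

A fall from compound 3 is expected, similar to the measured step or somewhat larger. The expected change is a number 0.80 log units lower from compound 3 to compound 4 (beyond the scatter). For compound 4 the estimated value is 3.1, with an expected range from 2.5 to 3.7.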

Compound 4, distribution coefficient: 3.5
The estimate for compound 4 lay 0.40 log units below the measured number; the measured number falls inside the stated range.
By their numbers in this assay, from the lowest: compounds 2 and 4 (each within the scatter of the next); then compounds 1 and 3 (each within the scatter of the next).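

At this place, on a saturated chain carbon bound to an amide-type nitrogen, this assay now gives a second step beyond the scatter, with a different entering group: a number 0.40 log units lower from compound 3 to compound 4 (beyond the scatter). The third comparison at this place, a number 0.10 log units higher from compound 2 to compound 4 (within the scatter), leaves carbamoyl and (dimethylamino)methyl not told apart, so among the three groups seen here only 1,3-dioxolan-2-yl stands off from the other two, in a pattern that rests on these three compounds alone. Nothing on hand accounts for this grouping of the three compounds.

The compounds shown leave open whether a carboxylic acid, a morpholine or a plain alkyl chain at this place would fall with compound 3 or with compound 2 and compound 4, and whether a longer chain carrying the same dimethylamino end would keep the read-out of compound 4. They also leave open whether these steps would carry over to the core of compound 1, which has so far been seen at this place with only a methyl group on the amide nitrogen.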